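Trimming the Hydroxyethyl Arm: From Compound 2 to Compound 3

The source may report more compounds than this note shows. Statements on the series, on what has been measured and on what is new or still open speak of the compounds shown alone.

Compound 1 `CC(C)(CO)NCc1nc2c(OCC3CCCCC3)cccc2[nH]1` gives 54.7% in an assay on cells for inhibition of interleukin-5 receptor subunit alpha (Mus musculus), read by WST assay, with a stated time of 48 h, tested at 30 uM, in the presence of a further agent that is not named here; on this read-out lower numbers stand for less inhibition and higher numbers for more inhibition at the one concentration tested (going by the name of the read-out).
Compound 2 `OCCC(NCc1nc2c(OCC3CCCCC3)cccc2[nH]1)c1ccccc1` gives 64.7% in this assay.

Compound 2 has the higher of these two numbers, yet compound 1 stands only a short way below it, within the usual scatter, so no order between the two can be read. Compound 3 `c1ccc(CNCc2nc3c(OCC4CCCCC4)cccc3[nH]2)cc1` differs from compound 2 by hydrogen in place of 2-hydroxyethyl on a saturated chain carbon bound to an amine nitrogen and an aromatic carbon. Within the data shown here, no step of this kind has been measured, so its size is open; a shift no larger than the scatter, if anything a little downward, is expected. Compound 3 is expected to give 55% in this assay, within 35% to 75%. The expected step is a number 9.7 percentage points lower from compound 2 to compound 3 (within the scatter).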

Compound 3, a percentage reported as inhibition, at one concentration (the size of the read-out at that concentration, not a potency): 49.3%
Beside the measured number, compound 3's estimate is 5.7 percentage points above it; the range from low to high includes it.
By their numbers in this assay, from the lowest: compounds 3, 1 and 2 (each within the scatter of the next, the first and the last beyond it).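

In this assay, hydrogen in place of 2-hydroxyethyl on the saturated chain carbon bound to an amine nitrogen and an aromatic carbon gives a number 15.4 percentage points lower from compound 2 to compound 3 (beyond the scatter), so removing this arm has a modest but readable effect. Benzyl in place of 1-(hydroxymethyl)-1-methylethyl on an amine nitrogen gives a number 5.4 percentage points lower from compound 1 to compound 3 (within the scatter), so no order can be read for that pair. Nothing in hand gives a reason for either step.

Still open, on these data alone, is whether the step follows the oxygen of the arm or its carbons. An ethyl or 2-aminoethyl group at the same place would help separate the two.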